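Series notes: methoxy in place of bromo, compound 4

This account rests on a few compounds, and the source may have more. Where it says the series, first, only, none or still open, it means among the compounds named here.

Measured compounds:
compound 1 `CC(O)CCn1nc2c(Br)c(Br)c(Br)c(Br)c2n1`: 79%
compound 2 `OC(CCn1nc2c(Br)c(Br)c(Br)c(Br)c2n1)c1ccc(Cl)cc1`: 100%
compound 3 `OC(CCn1nc2c(Br)c(Br)c(Br)c(Br)c2n1)c1cccc(Br)c1`: 102%

In a functional assay on MCF7 cells (Homo sapiens) for antiproliferative activity, read by MTT assay, with a stated time of 48 h, tested at 12.5 uM (a lower number here means a stronger effect, a higher number a weaker effect of the compound at the concentration tested), compound 3 gives the highest of the three numbers. The step of a number 2 percentage points higher from compound 2 to compound 3 (within the scatter) is within the scatter, whereas a number 23 percentage points higher from compound 1 to compound 3 (beyond the scatter) and a number 21 percentage points higher from compound 1 to compound 2 (beyond the scatter) lie beyond it; both of the latter replace methyl with an aryl group and are modest.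

Compound 4 `COc1cccc(C(O)CCn2nc3c(Br)c(Br)c(Br)c(Br)c3n2)c1` differs from compound 3 in one place: methoxy in place of bromo on an aromatic carbon. Among the measured compounds shown here, the only measured step that changes the aryl substituent rather than adding the aryl group is a number 2 percentage points higher from compound 2 to compound 3 (within the scatter), and it stays within the scatter. For the measured compounds named here, no measured step bears on a methoxy group. The two modest steps from compound 1 concern a different change and give no basis for expecting a further rise from compound 3.

The expected step is therefore a number 2 percentage points lower from compound 3 to compound 4 (within the scatter), none beyond the scatter. Compound 4 is estimated to give 100% in this assay, with a range from 88% to 112%.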

Compound 4, a percentage reported as activity, at one concentration (the size of the read-out at that concentration, not a potency): 97%
Estimate against measurement, compound 4: 3 percentage points above; the range from low to high includes it.
By their numbers in this assay, from the lowest: compound 1; then compounds 4, 2 and 3 (each within the scatter of the next).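

In this assay, replacing the bromo of 3-bromophenyl with methoxy adds a hydrogen-bond acceptor on this aromatic carbon yet gives a number 5 percentage points lower from compound 3 to compound 4 (within the scatter) and the comparison with the 4-chlorophenyl analogue gives a number 3 percentage points lower from compound 2 to compound 4 (within the scatter) so an oxygen-linked substituent here reads the same as the two halogen-bearing aryl groups. The step from methyl to an aryl group also holds without a halogen on the ring, with a number 18 percentage points higher from compound 1 to compound 4 (beyond the scatter) and compound 1 alone stands apart from compounds 2, 3 and 4. No measurement available here accounts for these steps.

On these data alone, whether an amine or a carboxylic acid on this aromatic carbon would shift the read-out remains open. So does whether any of these compounds differ in potency, since a single concentration gives only the size of the read-out.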